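Methyl for fluoro on the benzyl arm of compound 3

The source may report more compounds than this note shows. Statements on the series, on what has been measured and on what is new or still open speak of the compounds shown alone.

Compound 1 `COc1cccc(-c2nc(N)nc(NCc3ccccc3)n2)c1CO` gives 4.16 in a functional assay on cells for positive allosteric modulation of G-protein coupled receptor 68 (Homo sapiens), read by a luciferase reporter and cAMP accumulation, with a stated time of 30 min, at pH 6.8 and pH 8.3, in the presence of a further agent that is not named here; a higher number here means a more potent compound, by a factor of ten per unit of this negative logarithm, a lower number a less potent compound.
Compound 2 `CCOc1ccc(-c2nc(N)nc(NCc3ccccc3)n2)c(CO)c1` gives 4.37 in this assay.
Compound 3 `Nc1nc(NCc2cccc(F)c2)nc(-c2ccccc2CO)n1` gives 4.52 in this assay.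

Among these three numbers compound 3 has the highest, but compound 2 lies within the usual scatter of it, so the two cannot be ordered; only compound 1 sits clearly lower. Compound 4 `Cc1cccc(CNc2nc(N)nc(-c3ccccc3CO)n2)c1` differs from compound 3 by methyl in place of fluoro on an aromatic carbon. For the measured compounds named here, no measured pair shows this particular change, so there is no step to lean on. A swap of one small uncharged atom for another of the same size, away from the shared core, is expected to move this assay little, if at all, with no direction favoured: the expected step of a number 0.02 log units lower from compound 3 to compound 4 (within the scatter) stays within the scatter. Compound 4 is therefore estimated at 4.5, within a range from 4.1 to 4.9.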

Compound 4, negative logarithm of the antagonist equilibrium constant: 4.4
Beside the measured number, compound 4's estimate is 0.10 log units above it, and the stated range covers the measured number.
By their numbers in this assay, from the lowest: compounds 1, 2, 4 and 3 (each within the scatter of the next, the first and the last beyond it).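

Methyl in place of fluoro on this aromatic carbon gives a number 0.12 log units lower from compound 3 to compound 4 (within the scatter) in this assay and is the first step read at this place on the benzyl arm. Within this pair, 3-fluorobenzyl and 3-methylbenzyl cannot be told apart, a result that none of the earlier compounds could give. Nothing at hand bears on why the two groups read alike.

The compounds shown leave open whether methoxy, an amine or a carboxylic acid at this place would move the number. They also leave open how either group compares with plain hydrogen on this same pair.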